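Heteroaryl sulfonamide variation in a cytotoxicity series

The source may hold more compounds than are shown below. What is called first, only, known or untested is meant among the compounds shown, and "the series" means these compounds.

Measured so far in a functional assay on T47D cells (Homo sapiens) for cytotoxicity, read by sulforhodamine B assay, with a stated time of 48 h; on this read-out lower numbers stand for stronger inhibition and higher numbers for weaker inhibition:
compound 1 `CN(C)/C=C/C(=O)c1cc2ccccc2oc1=O` gives 147000 nM
compound 2 `O=C(/C=C\Nc1ccc(S(=O)(=O)Nc2ccccn2)cc1)c1cc2ccccc2oc1=O` gives 37600 nM
compound 3 `O=C(/C=C\Nc1ccc(S(=O)(=O)Nc2ncccn2)cc1)c1cc2ccccc2oc1=O` gives 75200 nM

Compound 2 stands at the lowest number of the three in this assay. Compound 3 sits nearest to it, with a 2.0-fold higher number from compound 2 to compound 3 (0.30 log units; within the scatter), and compound 1, which carries a dimethylamino group in place of the whole arylamino sulfonamide part, stands furthest, at a number beyond the scatter from compound 2.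

The unmeasured compound 4 `Cc1cc(NS(=O)(=O)c2ccc(N/C=C\C(=O)c3cc4ccccc4oc3=O)cc2)nc(C)n1` differs from compound 2 in one place: 2,6-dimethylpyrimidin-4-yl in place of pyridin-2-yl on a sulfonamide nitrogen. Within the data shown here, only one measured step bears on this change, the exchange of the heteroaryl group on the sulfonamide nitrogen, and that step, a 2.0-fold higher number from compound 2 to compound 3 (0.30 log units; within the scatter), stayed within the scatter. A second pyrimidine variant with two methyl groups is therefore expected to land near compound 2 or somewhat higher in this assay, with no firm basis for a step beyond the scatter in either direction, though a mild drift to a higher number is the more likely side given that compound 3 also moved that way.

For compound 4 the expected step is a 1.6-fold higher number from compound 2 to compound 4 (0.20 log units; within the scatter). The estimated value for compound 4 in this assay is 60000 nM, with a range from 25000 nM to 150000 nM.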

Compound 4, half-maximal inhibitory concentration: 100000 nM
The estimate for compound 4 lay 1.7-fold (0.22 log units) below the measured number, within the range that was stated.
By their numbers in this assay, from the lowest: compounds 2, 3, 4 and 1 (each within the scatter of the next, the first and the last beyond it).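

In this assay, the group on the sulfonamide nitrogen now proves able to move the number beyond the scatter: a 2.7-fold higher number from compound 2 to compound 4 (0.42 log units; beyond the scatter), whereas the earlier exchange at this place gave only a 2.0-fold higher number from compound 2 to compound 3 (0.30 log units; within the scatter). The two pyrimidine-bearing compounds cannot be separated from each other, with a 1.3-fold higher number from compound 3 to compound 4 (0.12 log units; within the scatter), so only 2,6-dimethylpyrimidin-4-yl stands clearly apart from pyridin-2-yl, and the shift to a higher number on leaving pyridin-2-yl holds beyond the scatter for compound 4 but not for compound 3. No accompanying data bear on the origin of this step, and the larger group and the extra ring nitrogen counted for compound 4 remain a plain structural description with no effect assigned to either.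

From the compounds shown here alone, the share of the two methyl groups in this step stays open, and an unsubstituted pyrimidin-4-yl group on the sulfonamide nitrogen would address it directly. Also open, going by these compounds, is whether a thiazol-2-yl group, a plain phenyl ring or a simple hydrogen at the same place would give a number lower than that of compound 2, which so far marks the low end of the series.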